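Ethoxy entering the carbamate side chain of the aziridinyl quinone series

A few compounds are considered here, and "the series" means these few. Any claim that something is new, unique, unknown or untested is made for them only; others in the source may bear on it.

Two compounds have numbers in a functional assay on L1210 cells (Mus musculus), with a stated time of 1 days; on this read-out higher numbers stand for higher potency (the scale is a negative logarithm) and lower numbers for lower potency. Compound 1 `CCOC(COC(N)=O)C1=C(N2CC2)C(=O)C(C)=C(N2CC2)C1=O` gives 5.53 in this assay. Compound 2 `CCC1=C(N2CC2)C(=O)C(CCOC(N)=O)=C(N2CC2)C1=O` gives 5.98 in this assay, the higher of the two numbers, beyond the scatter from compound 1. Compound 3 `CCOC(COC(N)=O)C1=C(N2CC2)C(=O)C(CC)=C(N2CC2)C1=O` is not yet measured; it differs from compound 2 by ethoxy in place of hydrogen on a saturated chain carbon bound to a double-bonded ring carbon and a saturated chain carbon. Within the data shown here, no step between measured compounds exists for this change. A modest decrease is expected, so that compound 3 is estimated at 5.7, between 5.25 and 6.15. The expected step of a number 0.28 log units lower from compound 2 to compound 3 (within the scatter) is small and may not exceed the scatter.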

Compound 3, logarithm of the reciprocal of the active concentration, log(1/C): 5.4
The estimate for compound 3 lay 0.30 log units above the measured number; the range from low to high includes it.
By their numbers in this assay, from the lowest: compounds 3 and 1 (each within the scatter of the next); then compound 2.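

In this assay, ethoxy in place of hydrogen on a saturated chain carbon bound to a double-bonded ring carbon and a saturated chain carbon gives a number 0.58 log units lower from compound 2 to compound 3 (beyond the scatter), so this position does not tolerate the change without a loss. Methyl in place of hydrogen on a saturated chain carbon bound to a double-bonded ring carbon gives a number 0.13 log units lower from compound 1 to compound 3 (within the scatter), so that change is not resolved on this read-out. Nothing measured on these compounds accounts for the ethoxy step.

From the compounds shown here alone, whether a smaller methoxy, a longer alkoxy chain or an amine on the same carbon would follow ethoxy remains open.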